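This account rests on a few compounds, and the source may have more. Where it says the series, first, only, none or still open, it means among the compounds named here.

Measured compounds:
compound 1, `CC(C)(C)OC(=O)N1CCC(CCCNc2ccc3c(c2)C(=O)CO3)CC1`: 262 nM
compound 2, `CCc1cnc(N2CCC(CCCNc3ccc4c(c3)OCC4=O)CC2)nc1`: 159 nM

In a functional assay on CHO-K1 cells for agonist activity at Glucose-dependent insulinotropic receptor (Mus musculus), read by HTRF and cAMP accumulation, with a stated time of 30 min (on this read-out higher numbers stand for an effect only at larger amounts of compound and lower numbers for an effect already at smaller amounts), compound 1 gives 262 nM, and in the same assay compound 2 gives 159 nM. Among the compounds with values here, compound 2 thus stands at one of only two numbers, and the gap between compound 2 and compound 1 is within the scatter, so the two cannot be told apart on these data.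

Compound 3, `CC(C)c1nsc(N2CCC(CCCNc3ccc4c(c3)OCC4=O)CC2)n1`, differs from compound 2 in one place: 3-isopropyl-1,2,4-thiadiazol-5-yl in place of 5-ethylpyrimidin-2-yl on an amine nitrogen in a ring. Within the data shown here, no step between measured compounds touches this part of the molecule, so there is nothing to carry over. With an aromatic ring of similar size again attached to the amine nitrogen in the ring, no step beyond the scatter is expected in this assay from compound 2 to compound 3. For compound 3 the expected value in this assay is 150 nM, with a range from 50 nM to 450 nM. This estimate means a step of a 1.1-fold lower number from compound 2 to compound 3 (0.03 log units; within the scatter).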

Compound 3, half-maximal effective concentration: 812 nM
Compound 3: middle estimate off by 5.4-fold (0.73 log units), on the low side, outside the stated range (above it).
By their numbers in this assay, from the lowest: compounds 2 and 1 (each within the scatter of the next); then compound 3.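

The group on the amine nitrogen in the six-membered non-aromatic ring proves not to be freely exchangeable: in this assay, 3-isopropyl-1,2,4-thiadiazol-5-yl in place of 5-ethylpyrimidin-2-yl gives a 5.1-fold higher number from compound 2 to compound 3 (0.71 log units; beyond the scatter) although both groups have the same number of heavy atoms and neither carries a net charge. Compound 1 and compound 2 could not show this, as they stand within the scatter of each other and differ in more than one place. No measurement at hand accounts for the step.

The compounds shown leave open whether the step goes with the five-membered ring, the sulfur or the isopropyl group, as no pair separates these. They also do not tell how a 5-ethylpyridin-2-yl or a 3-methyl-1,2,4-thiadiazol-5-yl group would stand at this nitrogen.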